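Adding a Second Chloro to Compound 3

This account rests on a few compounds, and the source may have more. Where it says the series, first, only, none or still open, it means among the compounds named here.

Three compounds were measured in an ADME assay on the whole organism with Oryza sativa as the target, tested at 10 uM; a lower number here means a stronger effect, a higher number a weaker effect of the compound at the concentration tested:
Compound 1, `CC(C)c1cccc(NC(=O)N[C@@H](C)c2ccccc2)c1`, gives 86%.
Compound 2, `C[C@H](NC(=O)Nc1cccc(F)c1)c1ccccc1`, gives 88%.
Compound 3, `C[C@H](NC(=O)Nc1cccc(Cl)c1)c1ccccc1`, gives 103%.

Compound 3 stands highest of the three in this assay. Its nearest neighbour is compound 2, the gap being a number 15 percentage points higher from compound 2 to compound 3 (beyond the scatter), and the furthest is compound 1, with a number 17 percentage points higher from compound 1 to compound 3 (beyond the scatter); both gaps lie beyond the scatter. Between compound 1 and compound 2 the difference is only a number 2 percentage points higher from compound 1 to compound 2 (within the scatter), which lies within the scatter, so no order is claimed between those two.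

Compound 4, `C[C@H](NC(=O)Nc1ccc(Cl)c(Cl)c1)c1ccccc1`, has not yet been measured. The change from compound 3 is chloro in place of hydrogen on an aromatic carbon.

Going by the values given here, two measured steps bear on the entry of a chloro group: a number 17 percentage points higher from compound 1 to compound 3 (beyond the scatter) and a number 15 percentage points higher from compound 2 to compound 3 (beyond the scatter), each a modest rise beyond the scatter. Among the compounds with values here, no measured step places a second chloro group on a ring that already carries one, and compound 3 already sits at the top of the measured range. The step is therefore expected to be small, a number 1 percentage points higher from compound 3 to compound 4 (within the scatter), most likely within the scatter and, if anything, upward. Compound 4 is estimated to give 104% in this assay, within the range from 88% to 120%.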

Compound 4, a percentage reported as activity, at one concentration (the size of the read-out at that concentration, not a potency): 99%
For compound 4 the middle estimate is 5 percentage points above the measured one; low and high end bracket the measured number.
By their numbers in this assay, from the lowest: compounds 1 and 2 (each within the scatter of the next); then compounds 4 and 3 (each within the scatter of the next).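

In this assay, a chloro group placed on an aromatic carbon that carried only hydrogen, ortho to a chloro group and para to a large group, gives a number 4 percentage points lower from compound 3 to compound 4 (within the scatter) and so shows that this position can take a second chloro group on the ring without a read-out separable from that of compound 3. The earlier steps shown here could not show this, since they only exchanged one group for another on a ring carbon that was already substituted, and one of them, chloro in place of fluoro, gave a number 15 percentage points higher from compound 2 to compound 3 (beyond the scatter) as a step that does clear the scatter. Nothing in hand bears on why the second chloro group leaves the number within the scatter of compound 3.

The compounds shown leave open whether a different group on this same carbon, such as methoxy, an amine or a carboxylic acid, would give a step beyond the scatter. They also leave open whether a chloro group at this position would read the same on a ring without the first chloro group, or with fluoro or isopropyl in its place.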